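The source may report more compounds than this note shows. Statements on the series, on what has been measured and on what is new or still open speak of the compounds shown alone.

Measured so far, in an assay on isolated protein (artery, Oryctolagus cuniculus) with Substance-P receptor (Homo sapiens) as the target; on this read-out higher numbers stand for weaker binding and lower numbers for tighter binding:
Compound 3, `CNS(=O)(=O)N1CCN(C2CN(CCC3(c4ccc(Cl)c(Cl)c4)CCC(=O)N(CC4CC4)C3)C2)CC1`, gives 3.16 nM.
Compound 1, `O=C1CCC(CCN2CC(N3CCOCC3=O)C2)(c2ccc(Cl)c(Cl)c2)CN1Cc1ccccc1`, gives 2.51 nM.
Compound 2, `O=C1CCC(CCN2CC(N3CCC(O)C3)C2)(c2ccc(Cl)c(Cl)c2)CN1Cc1ccccc1`, gives 2 nM.

Compound 3 gives the highest of the three numbers, yet both compound 1 and compound 2 lie within the scatter of it, so no order among the three can be read. Compound 4, `CS(=O)(=O)NC1CCN(C2CN(CCC3(c4ccc(Cl)c(Cl)c4)CCC(=O)N(CC4CC4)C3)C2)CC1`, differs from compound 3 by 4-(methanesulfonamido)piperidin-1-yl in place of 4-(methylsulfamoyl)piperazin-1-yl on a saturated ring carbon. Among the measured compounds shown here, no measured step covers this exchange. For the measured compounds named here, the only step on the same saturated ring carbon, a 1.3-fold lower number from compound 1 to compound 2 (0.10 log units; within the scatter), swapped one saturated heterocycle for another and stayed within the scatter. On that basis the expected change is a 1.0-fold higher number from compound 3 to compound 4 (0.01 log units; within the scatter), with no direction beyond the scatter. Compound 4 is therefore estimated at 3.2 nM, within a range from 1.2 nM to 8.5 nM.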

Compound 4, dissociation constant: 10 nM
Compound 4: the middle estimate sits 3.1-fold (0.49 log units) below what was measured, and the stated range ends below it.
By their numbers in this assay, from the lowest: compounds 2, 1 and 3 (each within the scatter of the next); then compound 4.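

In this assay, a 3.2-fold higher number from compound 3 to compound 4 (0.50 log units; beyond the scatter), a modest step but the first shown on this saturated ring carbon of the four-membered ring to lie beyond the scatter. The exchange keeps the heavy-atom, hydrogen-bond donor and acceptor counts unchanged, so equal counts did not guarantee an equal read-out here. Nothing shown accounts for the step. The compounds shown leave open whether the change of ring or the rearranged sulfonyl linkage carries the step. Going by these compounds, how a plain amine or a carboxylic acid on the six-membered ring would read also remains open.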